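Trifluoromethyl for Fluoro on the Aryl Ring of Compound 1

The source may hold more compounds than are shown below. What is called first, only, known or untested is meant among the compounds shown, and "the series" means these compounds.

Compound 1, `CCC(C(=O)N1CCN(c2ccccc2F)CC1)N1C(=O)CCC1=O`, is the stronger of the two measured compounds. In a functional assay on the whole organism (strain Swiss) with Mus musculus as the target, in the maximal electroshock model, with a stated time of 0.25 h, at a dose of 300 mg/kg by the intraperitoneal route (on this read-out lower numbers stand for a weaker effect and higher numbers for a stronger effect at the one dose given), compound 1 gives 100%, while compound 2, `CCC(C(=O)N1CCN(c2ccc(Cl)cc2)CC1)N1C(=O)CCC1=O`, gives 0%. Among the measured compounds shown here, the single measured step, a number 100 percentage points lower from compound 1 to compound 2 (beyond the scatter), shows that the ring substituent on the amine nitrogen matters greatly, but it alters both the group and where it sits at once, so it speaks only indirectly to the change now in view.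

Compound 3, `CCC(C(=O)N1CCN(c2ccccc2C(F)(F)F)CC1)N1C(=O)CCC1=O`, differs from compound 1 by trifluoromethyl in place of fluoro on an aromatic carbon. For the measured compounds named here, the substituent stays on the same aromatic carbon, ortho to the large group, so the one measured step does not directly describe this exchange; it only warns that the read-out can swing across its whole span with a change on this ring. Because compound 1 stands at 100%, there is no room for a gain, and the expected outcome is a loss of uncertain size, a number 40 percentage points lower from compound 1 to compound 3 (beyond the scatter). Compound 3 is therefore estimated at 60%, with a range from 10% to 100%.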

Compound 3, a percentage reported as activity, at one dose (the size of the read-out at that dose, not a potency): 25%
Beside the measured number, compound 3's estimate is 35 percentage points above it; the range from low to high includes it.
By their numbers in this assay, from the lowest: compound 2; then compound 3; then compound 1.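

In this assay, keeping the substituent on the same aromatic carbon, ortho to a large group, and exchanging only fluoro for trifluoromethyl gives a number 75 percentage points lower from compound 1 to compound 3 (beyond the scatter). The earlier step changed the group and its place together, whereas this one changes the group alone, and so shows that the identity of the substituent at this position by itself moves the read-out well beyond the scatter. The exchange does not remove the effect entirely, since compound 3 still gives 25%, but nothing measured here explains the loss or says which difference between the two groups accounts for it.

The compounds shown leave open how a chloro, methyl or methoxy group would read on this same aromatic carbon, and so whether fluoro is unusual here or whether trifluoromethyl is the exception. They also leave open whether trifluoromethyl would give a similar result on another carbon of the aromatic ring, and how compound 1 and compound 3 would compare at other doses or times, as this read-out gives the size of the effect at one dose and not a potency.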